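A few compounds are considered here, and "the series" means these few. Any claim that something is new, unique, unknown or untested is made for them only; others in the source may bear on it.

In a functional assay on THP-1 cells (Homo sapiens) for inhibition, read by ELISA, with stated times of 1 h and 18 h (a higher number here means a weaker inhibitor, a lower number a stronger inhibitor), compound 1 `NC(=O)[C@@H]1[C@H](Nc2nc(Nc3cccc(C(=O)N4CCCC4)c3)ncc2-c2cccnc2)[C@H]2C=C[C@@H]1C2` gives 320 nM, while compound 2 `NC(=O)[C@@H]1[C@H](Nc2nc(Nc3cccc(C(=O)N4CCCC4)c3)ncc2-c2ccccc2F)[C@H]2C=C[C@@H]1C2` gives 130 nM, the lower of the two numbers and so the stronger inhibitor of the pair. Compound 3 `N#Cc1cccc(-c2cnc(Nc3cccc(C(=O)N4CCCC4)c3)nc2N[C@H]2[C@@H](C(N)=O)[C@@H]3C=C[C@H]2C3)c1` keeps the shared core and differs from compound 2 at one place: 3-cyanophenyl in place of 2-fluorophenyl on an aromatic carbon. Here 3-cyanophenyl stands in place of 2-fluorophenyl on an aromatic carbon. Going by the values given here, only one measured step bears on this change, and it concerns the same place: a 2.5-fold lower number from compound 1 to compound 2 (0.39 log units; beyond the scatter), a modest step beyond the scatter, with 2-fluorophenyl replacing pyridin-3-yl. Among the compounds with values here, no measured compound carries a nitrile, so the direction is uncertain. A change no larger than that modest step is expected in this assay, leaning slightly towards a higher number. The estimated step is a 1.5-fold higher number from compound 2 to compound 3 (0.16 log units; within the scatter). The expected value for compound 3 is 190 nM, within an estimated range of 70 nM to 500 nM.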

Compound 3, half-maximal inhibitory concentration: 280 nM
Estimate against measurement, compound 3: 1.5-fold (0.17 log units) below, within the range that was stated.
By their numbers in this assay, from the lowest: compound 2; then compounds 3 and 1 (each within the scatter of the next).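

Swapping 2-fluorophenyl for 3-cyanophenyl gives a 2.2-fold higher number from compound 2 to compound 3 (0.33 log units; beyond the scatter) in this assay, so the advantage of 2-fluorophenyl at this position does not extend to every substituted phenyl group. With a 1.1-fold lower number from compound 1 to compound 3 (0.06 log units; within the scatter), 3-cyanophenyl and pyridin-3-yl cannot be told apart here, leaving compound 2 as the only one of the three whose steps to both others are beyond the scatter. Nothing available explains this ordering.

Compound 2 and compound 3 differ in both the substituent and its place on the phenyl ring, so the compounds shown do not separate the contribution of the group from that of its location. On these data alone, it also remains open how this position would respond to a phenyl ring carrying an amine or a carboxylic acid.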